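Removing a Phenolic Hydroxy From an Inactive Amide

This account rests on a few compounds, and the source may have more. Where it says the series, first, only, none or still open, it means among the compounds named here.

Compound 1 `O=C(Nc1ccc(O)cc1)C1CCc2ccccc2N1`: in a functional assay on PC-3 cells (Homo sapiens) for cytotoxicity, read by sulforhodamine B assay, with a stated time of 72 h (on this read-out lower numbers stand for stronger inhibition of growth and higher numbers for weaker inhibition of growth), compound 1 gives > 100000 nM, which is a limit of the assay.
Compound 2 `CC(=O)N1c2ccccc2CCC1C(=O)Nc1ccccc1C(F)(F)F`: in this assay compound 2 gives > 80000 nM, also a limit of the assay.

Compound 1 therefore stands only at a limit, as the line the limit of > 100000 nM in this assay, at which 1 of the 2 values shown sits, shows, and compound 2 sits at the limit described by the limit of > 80000 nM in this assay, at which 1 of the 2 values shown sits. Neither value orders the two.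

Compound 3 `O=C(Nc1ccccc1)C1CCc2ccccc2N1` differs from compound 1 by hydrogen in place of hydroxy on an aromatic carbon. Within the data shown here, with no measured step to lean on, the expected change from compound 1 to compound 3 in this assay is a number no higher from compound 1 to compound 3 (the limit leaves the size open), none beyond the scatter. Compound 3 is estimated at 100000 nM, between 30000 nM and 300000 nM.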

Compound 3, concentration for 50% growth inhibition: 110000 nM
Compound 3: middle estimate off by 1.1-fold (0.04 log units), on the low side; the range from low to high includes it.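

No step can be read from compound 1 to compound 3, because compound 1 stands only at a limit of the assay: the limit of > 100000 nM in this assay, at which 1 of the 3 values shown sits.

The compounds shown leave open whether swapping the hydroxy for hydrogen changes growth inhibition at all in this assay.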